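The source may report more compounds than this note shows. Statements on the series, on what has been measured and on what is new or still open speak of the compounds shown alone.

Measured so far: compound 1 `C=CCn1c(=O)/c(=C\c2ccc(Cl)c(Cl)c2)[nH]c(=O)/c1=C\c1ccccc1OC` gives "not active" (no number reported) in a functional assay on U-937 cells (Homo sapiens) for cytotoxicity, read by CCK-8 assay, with a stated time of 72 h; on this read-out lower numbers stand for stronger inhibition and higher numbers for weaker inhibition; compound 2 `C=CCn1c(=O)/c(=C\c2ccccc2OC)[nH]c(=O)/c1=C\c1ccccc1OC` gives 5100 nM in this assay.

Among the compounds with values here, compound 2 therefore holds the only number recorded in this assay; compound 1, the sole other entry, is reported as not active and carries no figure, so no ordered step between the two can be stated. Compound 3 `C=CCn1c(=O)/c(=C\c2cccc(Br)c2)[nH]c(=O)/c1=C\c1ccccc1OC` is the next compound to be tested in this assay. It differs from compound 2 in one place: 3-bromophenyl in place of 2-methoxyphenyl on a double-bonded chain carbon bound to an aromatic carbon. Within the data shown here, no measured pair shows this change, so its size is unknown. The one related observation is that compound 1, which also carries a group other than 2-methoxyphenyl at that same place, gave "not active" (no number reported) in this assay. On that basis the step from compound 2 to compound 3 is expected to weaken inhibition, by an amount beyond the usual scatter, and there is a real chance that compound 3 yields no number at all. Compound 3 is estimated at 15000 nM in this assay, within a range of 5000 nM to 50000 nM, which corresponds to the expected step of a 2.9-fold higher number from compound 2 to compound 3 (0.47 log units; beyond the scatter).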

Compound 3, half-maximal inhibitory concentration: 1100 nM
For compound 3 the middle estimate is 14-fold (1.13 log units) above the measured one; the measured number lies below the stated range.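

In this assay, the place on a double-bonded chain carbon bound to an aromatic carbon tolerates the loss of 2-methoxyphenyl, since 3-bromophenyl there gives a 4.6-fold lower number from compound 2 to compound 3 (0.67 log units; beyond the scatter) and so improves on the parent group. Within the data shown here, until now the only other group at that place was the one in compound 1, and the contrast between compound 1 at "not active" (no number reported) and compound 3 at 1100 nM shows that the outcome depends on which group replaces 2-methoxyphenyl, not merely on its removal. Nothing available explains why the number fell with this change.

The compounds shown leave open whether the gain belongs to the bromine itself, as a phenyl ring with no substituent or a ring bearing a carboxylic acid or an amine at this place could help to tell. They also leave open how much the second 2-methoxyphenyl group and the allyl chain contribute, since both stay the same in all three compounds, and a longer chain in place of the allyl would bear on the latter.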